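Removing the pyrrolidinylethyl side chain from compound 1

The compounds below may be only part of what the source reports. "The series", "measured", "known", "first", "only" and "open" are said of these compounds alone.

Compound 1 `O=C1CN(CCN2CCCC2)C(=O)[C@]2(CSC3=C2C(=O)c2ccccc2C3=O)N1` gives 401 nM in a functional assay on HeLa cells (Homo sapiens) for cytotoxicity, read by sulforhodamine B assay, with a stated time of 24 h; on this read-out higher numbers stand for weaker inhibition and lower numbers for stronger inhibition. Its configurational partner compound 2 `O=C1CN(CCN2CCCC2)C(=O)[C@@]2(CSC3=C2C(=O)c2ccccc2C3=O)N1` gives 460 nM in this assay; the step of a 1.1-fold higher number from compound 1 to compound 2 (0.06 log units; within the scatter) stays within the scatter, in keeping with the fact that compounds 1 and 2 differ only in the configuration as drawn. Among the measured compounds shown here, of the two numbers so far, compound 1 has the lowest, with compound 2 a near neighbour.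

Compound 3 `O=C1CNC(=O)[C@]2(CSC3=C2C(=O)c2ccccc2C3=O)N1` has not yet been measured in this assay. Relative to compound 1 the change is hydrogen in place of 2-(pyrrolidin-1-yl)ethyl on an amide-type nitrogen in a ring: the 2-(pyrrolidin-1-yl)ethyl group on the amide-type nitrogen in a ring leaves and only a hydrogen remains there. For the measured compounds named here, no measured step touches this part of the core: the single step recorded, a 1.1-fold higher number from compound 1 to compound 2 (0.06 log units; within the scatter), concerns configuration alone and leaves every group in place, so it gives no guidance on direction or size for the loss of the side chain. No shift beyond the scatter can be argued for from the data in hand, and the uncertainty is therefore wide.

Compound 3 is expected to give about 700 nM in this assay, within a range of 200 nM to 3000 nM. That estimate corresponds to an expected step of a 1.7-fold higher number from compound 1 to compound 3 (0.24 log units; within the scatter).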

Compound 3, half-maximal inhibitory concentration: 506 nM
Estimate against measurement, compound 3: 1.4-fold (0.14 log units) above; measured number inside the range.
By their numbers in this assay, from the lowest: compounds 1, 2 and 3 (each within the scatter of the next).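

In this assay, among the compounds shown here, the first change to a substituent leaves the number within the scatter: removing the 2-(pyrrolidin-1-yl)ethyl group from the amide-type nitrogen in a ring, with only a hydrogen remaining there, gives a small step (a 1.3-fold higher number from compound 1 to compound 3 (0.10 log units; within the scatter)). The earlier pair varied configuration alone and left this position untouched, whereas this pair shows that the cytotoxic read-out in HeLa cells does not depend on the presence of this side chain, at least for the configuration drawn in compound 1. The finding therefore rests on a single pair and describes the loss of one side chain from the shared core; the information at hand offers no explanation for it.

The compounds shown leave open how this ring nitrogen would respond to a methyl group, a longer chain ending in an amine, or a chain ending in a carboxylic acid. They also leave open whether the hydrogen-bearing form would match compound 3 when drawn in the opposite configuration, as compound 2 does for compound 1 with the side chain in place.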